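Swapping the hydroxylated ring to reach compound 4

The source may hold more compounds than are shown below. What is called first, only, known or untested is meant among the compounds shown, and "the series" means these compounds.

compound 1 `N#Cc1cnc(NCc2cnccc2C(F)(F)F)cc1N[C@H]1C[C@@H](O)C1` gives 90%
compound 2 `N#Cc1cnc(NCc2cnccc2C(F)(F)F)cc1NC[C@H]1C[C@H](O)C1` gives 93%
compound 3 `N#Cc1cnc(NCc2ccccc2C(F)(F)F)cc1N[C@H]1CC[C@@H](O)CC1` gives 0%

All three were tested in an ADME assay on S9 fraction from liver (Homo sapiens) for metabolic stability, with a stated time of 1 h; a higher number here means that more of the compound is left, a lower number that less of the compound is left. Compound 2 sits at the top of this small set, level with compound 1 within the scatter and far beyond the scatter from compound 3 . Compound 4 `N#Cc1cnc(NCc2cnccc2C(F)(F)F)cc1N[C@H]1CC[C@H](O)CC1` is the next to be measured, and the change is 4-hydroxycyclohexyl in place of (3-hydroxycyclobutyl)methyl on a nitrogen on an aromatic ring. For the measured compounds named here, the one measured step at this nitrogen, a number 3 percentage points higher from compound 1 to compound 2 (within the scatter), stayed within the scatter. Compound 3 also carries a 4-hydroxycyclohexyl group and reads 0%, but it differs from compound 4 elsewhere too, so a real fall remains possible. A moderate fall is therefore expected, estimated as a number 18 percentage points lower from compound 2 to compound 4 (beyond the scatter), with wide uncertainty. For compound 4 the estimated value is 75%, with an expected range from 40% to 95%.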

Compound 4, percent of the compound remaining: 30%
Compound 4: the middle estimate sits 45 percentage points above what was measured; the measured number lies below the stated range.
By their numbers in this assay, from the lowest: compound 3; then compound 4; then compounds 1 and 2 (each within the scatter of the next).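

In this assay, the group on this nitrogen can matter a great deal: 4-hydroxycyclohexyl brings a number 63 percentage points lower from compound 2 to compound 4 (beyond the scatter), and a number 60 percentage points lower from compound 1 to compound 4 (beyond the scatter). For the compounds shown here, the earlier step here stayed within the scatter, so these are the first steps to show that changing this hydroxylated group can shift the number strongly. Nothing available bears on why the number falls. From the compounds shown here alone, it remains open whether the six-membered ring alone accounts for the fall, and how a 3-hydroxycyclopentyl group would read here. A cyclohexyl ring carrying an amine instead of the hydroxyl also remains an open case.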